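This account rests on a few compounds, and the source may have more. Where it says the series, first, only, none or still open, it means among the compounds named here.

Compound 1 `CN1[C@@H]2c3[nH]c4ccccc4c3C[C@H]1[C@H](C#N)N1[C@@H](CN3C(=O)c4ccccc4C3=O)c3[nH]c4ccccc4c3C[C@@H]21` is the reference point here. Among the compounds with values here, in a functional assay on A2780 cells (Homo sapiens) for cytotoxicity, read by MTT assay, with a stated time of 72 h (a lower number here means a stronger inhibitor, a higher number a weaker inhibitor), compound 1 gives 80 nM, the lowest of the three numbers measured so far; compound 2 `CN1[C@@H]2c3[nH]c4ccccc4c3C[C@H]1[C@H](C#N)N1[C@@H](CNC(=O)c3ccc(F)cc3)c3[nH]c4ccccc4c3C[C@@H]21` gives 250 nM and compound 3 `CN1[C@@H]2c3[nH]c4ccccc4c3C[C@H]1[C@H](C#N)N1[C@@H](CNC(=O)c3ccc4ccccc4c3)c3[nH]c4ccccc4c3C[C@@H]21` gives 1030 nM.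

Compound 4 `CN1[C@@H]2c3[nH]c4ccccc4c3C[C@H]1[C@H](C#N)N1[C@@H](CNC(=O)/C=C/c3ccccc3)c3[nH]c4ccccc4c3C[C@@H]21` differs from compound 1 in one place: a group of 11 heavy atoms (9 carbon, 1 nitrogen, 1 oxygen; one six-membered aromatic ring of carbon only) in place of a group of 11 heavy atoms (8 carbon, 1 nitrogen, 2 oxygen; one five-membered non-aromatic ring with 1 hetero atom, one six-membered aromatic ring of carbon only), on a saturated chain carbon bound to a saturated ring carbon. So the cyclic imide of compound 1 is exchanged for an open amide that carries a phenyl ring on a two-carbon unsaturated linker.

Two measured steps speak to this change. Within the data shown here, the first is the exchange of the same cyclic imide for an open amide in compound 2, which gave a 3.1-fold higher number from compound 1 to compound 2 (0.49 log units; beyond the scatter). The second is the exchange of one aromatic amide group for a larger one, which gave a 4.1-fold higher number from compound 2 to compound 3 (0.61 log units; beyond the scatter). Both moves weakened the inhibitor. Compound 4 also opens the imide to an amide, and its aromatic group is extended by the linker, so a weaker result than compound 1 is expected, probably of a size between those two steps. The expected step is a 4.4-fold higher number from compound 1 to compound 4 (0.64 log units; beyond the scatter). Compound 4 is therefore estimated at 350 nM, within a range of 120 nM to 1000 nM.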

Compound 4, half-maximal inhibitory concentration: 770 nM
Compound 4: middle estimate off by 2.2-fold (0.34 log units), on the low side; the range from low to high includes it.
By their numbers in this assay, from the lowest: compound 1; then compound 2; then compounds 4 and 3 (each within the scatter of the next).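

Opening the cyclic imide costs more here than in the earlier amide: in this assay, the ((2-phenylethenyl)carbonyl)amino group in place of the imide gives a 9.6-fold higher number from compound 1 to compound 4 (0.98 log units; beyond the scatter), so no open amide shown so far comes close to compound 1. The group on the carbonyl carbon also matters, and 4-fluorophenyl is the best of the three tried there: 2-phenylethenyl in its place gives a 3.1-fold higher number from compound 2 to compound 4 (0.49 log units; beyond the scatter), whereas 2-phenylethenyl in place of naphthalen-2-yl gives a 1.3-fold lower number from compound 3 to compound 4 (0.13 log units; within the scatter), which is within the scatter, so these two quite different groups cannot be told apart in this assay. No measurement is available that would explain these differences.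

Compound 1 is the only imide shown, so it stays open whether its low number belongs to the closed ring, to the absence of the amide hydrogen, or to the way its benzene ring is held. A simple acetyl amide, a free amine on the same saturated chain carbon, or a saturated 2-phenylethyl group on the carbonyl carbon would each add a new point to this comparison.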